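The source may hold more compounds than are shown below. What is called first, only, known or untested is meant among the compounds shown, and "the series" means these compounds.

For the measured compounds named here, in a functional assay on SNB-75 cells (Homo sapiens) for antiproliferative activity, read by sulforhodamine B assay, with a stated time of 48 h (a higher number here means a weaker inhibitor of growth, a lower number a stronger inhibitor of growth), two compounds that share one core have numbers so far. Compound 1 (`O=C(NCCCNc1cc(-c2cn(-c3ccccc3)nc2-c2cccc(O)c2)ccn1)Nc1ccc(F)cc1`) gives 3180 nM as its concentration for total growth inhibition, and compound 2 (`O=C(NCCCNc1cc(-c2cn(-c3ccccc3)nc2-c2cccc(O)c2)ccn1)Nc1cccc(C(F)(F)F)c1`) gives 4100 nM on the same read-out. These two values lie within the scatter of each other, so neither compound can be ranked ahead.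

Compound 3 (`COc1cccc(-c2nn(-c3ccccc3)cc2-c2ccnc(NCCCNC(=O)Nc3ccc(F)cc3)c2)c1`) differs from compound 1 at a single place (methyl in place of hydrogen on an oxygen on an aromatic ring): methyl in place of hydrogen on an oxygen on an aromatic ring, which turns 3-hydroxyphenyl into 3-methoxyphenyl. Going by the values given here, the only measured step, from compound 1 to compound 2 (a 1.3-fold higher number from compound 1 to compound 2 (0.11 log units; within the scatter)), swaps 3-(trifluoromethyl)phenyl for 4-fluorophenyl on an amide-type nitrogen. It therefore says nothing directly about this oxygen. Among the compounds with values here, it is only a weak hint that one small edit to compound 1 can leave the number unmoved, and no measurement yet shows what this change does. Going by these compounds, a step beyond the scatter is not expected, and the direction stays open. The estimated step is a 1.2-fold higher number from compound 1 to compound 3 (0.08 log units; within the scatter) and remains only an expectation. For compound 3 the expected value is 3800 nM (estimated range 1700 nM to 8500 nM).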

Compound 3, concentration for total growth inhibition: 22700 nM
Beside the measured number, compound 3's estimate is 6.0-fold (0.78 log units) below it, and the stated range ends below it.
By their numbers in this assay, from the lowest: compounds 1 and 2 (each within the scatter of the next); then compound 3.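

In this assay, the oxygen on the aromatic ring turns out to be a place where a very small edit counts: replacing its hydrogen with a methyl, a change of one carbon that turns 3-hydroxyphenyl into 3-methoxyphenyl, gives a 7.1-fold higher number from compound 1 to compound 3 (0.85 log units; beyond the scatter) and so means weaker growth inhibition. The earlier pair differed only in the group on the amide-type nitrogen and showed no step beyond the scatter, so this is the first single edit among the compounds shown that moves the number by more than the scatter. Nothing available explains why this methyl has such an effect.

Going by these compounds, it remains open whether any replacement at this place raises the number or only the methyl does, and an ethyl on the same oxygen or an amine in place of the hydroxy would help separate those two readings. On these data alone, it is also open whether the same edit gives a similar step when 3-(trifluoromethyl)phenyl, the group in compound 2, sits on the amide-type nitrogen instead of 4-fluorophenyl.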